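The source may report more compounds than this note shows. Statements on the series, on what has been measured and on what is new or still open speak of the compounds shown alone.

In a functional assay on the whole organism for antagonist activity, with Mus musculus as the target, in the maximal electroshock model (on this read-out lower numbers stand for an effect already at smaller amounts and higher numbers for an effect only at larger amounts of compound), compound 1 (`CC(=O)NC1=NC(c2ccccc2)CN1`) gives 54 mg/kg as its value and compound 2 (`CCC(=O)NC1=NC(c2ccccc2)CN1`) gives 75 mg/kg on the same read-out. Compound 3 (`COC(=O)NC1=NC(c2ccccc2C)CN1`) gives 55 mg/kg here, which lies within the scatter of both other values, so it holds no separate place among the three. Compound 4 (`COC(=O)NC1=NC(c2ccccc2F)CN1`) has no value yet. The change from compound 3 to compound 4 is fluoro in place of methyl on an aromatic carbon and nothing else in the structure differs.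

Among the compounds with values here, the one measured step is a 1.4-fold higher number from compound 1 to compound 2 (0.14 log units; within the scatter) and it concerns methyl in place of hydrogen on a saturated chain carbon bound to a carbonyl carbon, so it bears on the present change only loosely. Within the data shown here, no measured pair shows a swap on the aromatic ring, so the size of this swap remains unknown. Taking compound 3 at 55 mg/kg as the starting point, and with the step from compound 1 staying small, no step beyond the scatter is expected in this assay and no direction is favoured. The estimated step is no change at the digits printed from compound 3 to compound 4 (within the scatter) and it is expected to stay inside the scatter. For compound 4 the expected dose is 55 mg/kg with an estimated span of 28 mg/kg to 110 mg/kg around it.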

Compound 4, dose for half-maximal effect: 54 mg/kg
Compound 4: middle estimate off by 1.0-fold (0.01 log units), on the high side; low and high end bracket the measured number.
By their numbers in this assay, from the lowest: compounds 1, 4, 3 and 2 (each within the scatter of the next).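

In this assay, within the data shown here, the first measured swap on the aromatic ring, fluoro in place of methyl on an aromatic carbon ortho to a large group, gives a 1.0-fold lower number from compound 3 to compound 4 (0.01 log units; within the scatter), so this read-out does not separate the two groups at this position. With the rest of the structure held constant, methyl and fluoro, each a single heavy atom with no hydrogen-bond donors or acceptors, are interchangeable on this read-out, at least for this pair; one pair gives no trend across ring groups. No supporting measurement bears on why the number stays within the scatter across this swap, so the result stands as an observation only.

The compounds shown leave open whether a larger or differently built group at this carbon, such as methoxy, trifluoromethyl, an amine or a carboxylic acid, would give a step beyond the scatter. They also leave open what plain hydrogen at this carbon would give with the side chain of compound 3 and compound 4, and whether chloro or fluoro on another carbon of the ring would behave as fluoro does here.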